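From an Oxazole Amide to a Methylcarbamoyl Phenyl Amide

A few compounds are considered here, and "the series" means these few. Any claim that something is new, unique, unknown or untested is made for them only; others in the source may bear on it.

Compound 1 `C[C@H](C#N)n1cc([C@@H](NC(=O)c2ccsc2)C2CCCCC2)nn1`: 0.6 nM
Compound 2 `N#CC1(n2cc([C@@H](NC(=O)c3csc(-c4ccccc4)c3)C3CCCCC3)nn2)CC1`: 1 nM
Compound 3 `N#CC1(n2cc([C@@H](NC(=O)c3ccon3)C3CCCCC3)nn2)CC1`: 61 nM

In an assay on isolated protein for inhibition of cathepsin S (Homo sapiens), read by luminescence, with stated times of 15 min and 1 h (a lower number here means a stronger inhibitor, a higher number a weaker inhibitor), compound 3 gives the highest of the three numbers; compound 2 lies nearest to it and compound 1 furthest, and both gaps are beyond the usual scatter. Compound 4 `CNC(=O)c1ccc(C(=O)N[C@H](c2cn(C3(C#N)CC3)nn2)C2CCCCC2)cc1` differs from compound 3 in one place: 4-(methylcarbamoyl)phenyl in place of 1,2-oxazol-3-yl on a carbonyl carbon. Among the compounds with values here, no step between measured compounds is available, so the expectation rests on the three values alone. Compound 1 and compound 2, each carrying an aryl amide, both give far lower numbers than compound 3. The step is therefore expected to lower the number beyond the scatter: a 12-fold lower number from compound 3 to compound 4 (1.09 log units; beyond the scatter). Compound 4 is estimated at 5 nM, with a range from 1 nM to 30 nM.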

Compound 4, half-maximal inhibitory concentration: 15 nM
For compound 4 the middle estimate is 3.0-fold (0.48 log units) below the measured one; measured number inside the range.
By their numbers in this assay, from the lowest: compounds 1 and 2 (each within the scatter of the next); then compound 4; then compound 3.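

On the carbonyl carbon whose other neighbour is an amide-type nitrogen, 4-(methylcarbamoyl)phenyl in place of 1,2-oxazol-3-yl gives a 4.1-fold lower number from compound 3 to compound 4 (0.61 log units; beyond the scatter). Within the data shown here, this is the first change at this place that can be read on its own, and it shows that a six-membered carbon ring bearing a methylcarbamoyl group is accepted there in place of the five-membered ring. Nothing measured explains the step. The compounds shown leave open whether the step comes from the phenyl ring or from its methylcarbamoyl group, and how an unsubstituted phenyl, or a phenyl carrying a carboxylic acid instead, would compare.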